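The source may hold more compounds than are shown below. What is called first, only, known or untested is meant among the compounds shown, and "the series" means these compounds.

Measured so far in a toxicity assay on cells (Macrophage, Homo sapiens) for inhibition, read by MTT assay; on this read-out higher numbers stand for weaker inhibition and lower numbers for stronger inhibition:
- compound 1 `CN(C)CCNc1nc(-c2ccc(Cl)cc2)nc2ccccc12`: 60000 nM
- compound 2 `COc1ccc(-c2nc(NCCN(C)C)c3ccccc3n2)cc1`: 57000 nM
- compound 3 `COc1ccc(-c2nc(NCCCN3CCN(C)CC3)c3ccccc3n2)cc1`: 53000 nM

Compound 2 gives 57000 nM and lies within the scatter of both other compounds, so the three values cannot be told apart. Compound 4 `COc1ccc(-c2nc(NCCN(C)C)c3ccccc3n2)cc1O` has not yet been measured in this assay. It differs from compound 2 by hydroxy in place of hydrogen on an aromatic carbon, which is hydroxy in place of hydrogen on an aromatic carbon, ortho to a methoxy group.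

For the measured compounds named here, two measured steps bear on this change, though only indirectly. Going by the values given here, the first is a swap on an aromatic carbon, methoxy in place of chloro, and it gave a 1.1-fold lower number from compound 1 to compound 2 (0.02 log units; within the scatter). The second is a change on the saturated chain, and it gave a 1.1-fold lower number from compound 2 to compound 3 (0.03 log units; within the scatter). Among the compounds with values here, neither step introduces a hydroxy group, and no measured compound carries one, so the data leave this change itself untested. Since both changes that were made stayed within the scatter, no step beyond the scatter is expected here, and any drift could go in either direction. The expected step is a 1.1-fold lower number from compound 2 to compound 4 (0.06 log units; within the scatter), an estimate and not a measurement. Compound 4 is estimated at 50000 nM, with an expected range from 25000 nM to 95000 nM.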

Compound 4, half-maximal inhibitory concentration: 22500 nM
Estimate against measurement, compound 4: 2.2-fold (0.35 log units) above; measured number outside the range, below it.
By their numbers in this assay, from the lowest: compound 4; then compounds 3, 2 and 1 (each within the scatter of the next).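

In this assay, adding a hydroxy group ortho to a methoxy group and meta to a large group gave a 2.5-fold lower number from compound 2 to compound 4 (0.40 log units; beyond the scatter), the only step among those shown that lies beyond the scatter. For the compounds shown here, the two earlier changes, methoxy in place of chloro and the change on the saturated chain, had left the number within the scatter, so this addition of a single oxygen-bearing group on the aromatic carbon is the first change seen to shift the read-out, and it shifts it towards stronger inhibition, though only modestly. Nothing available accounts for this step, and the result stands as an observation without an established cause.

The compounds shown leave open whether the step is specific to the hydroxy group, since it is unknown whether an amine, a fluoro group or a second methoxy group on the same aromatic carbon would give a similar shift. They also leave open whether the hydroxy group would have the same effect without the methoxy group ortho to it, or alongside the (4-methylpiperazin-1-yl)methyl group of compound 3.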